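The source may report more compounds than this note shows. Statements on the series, on what has been measured and on what is new or still open speak of the compounds shown alone.

In a toxicity assay on GES1 cells (Homo sapiens) for inhibition, read by MTT assay, with a stated time of 72 h (on this read-out higher numbers stand for weaker inhibition and lower numbers for stronger inhibition), the compounds share one core and differ in the group on a saturated chain carbon bound to a sulfur. Compound 3 `Cc1cc(N2CC[C@@H](C)[C@@H](N(C)c3ncnc4[nH]ccc34)C2)n2nc(SCC3CCCCC3)nc2n1` gives 98200 nM and compound 2 `Cc1cc(N2CC[C@@H](C)[C@@H](N(C)c3ncnc4[nH]ccc34)C2)n2nc(SCCc3ccccc3)nc2n1` gives 66200 nM, and the gap, a 1.5-fold higher number from compound 2 to compound 3 (0.17 log units; within the scatter), stays within the scatter. Compound 1 `Cc1cc(N2CC[C@@H](C)[C@@H](N(C)c3ncnc4[nH]ccc34)C2)n2nc(SCc3ccc(Cl)cc3)nc2n1` reaches only a limit of the assay, > 100000 nM. This is the limit of > 100000 nM in this assay, at which 1 of the 3 values shown sits.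

Compound 4 `Cc1ccc(CSc2nc3nc(C)cc(N4CC[C@@H](C)[C@@H](N(C)c5ncnc6[nH]ccc56)C4)n3n2)cc1` has not yet been measured. It departs from compound 3 by 4-methylphenyl in place of cyclohexyl on a saturated chain carbon bound to a sulfur. Among the measured compounds, compound 1 carries the group closest to the entering one, a 4-chlorophenyl. The step that bears most directly is therefore an at least 1.0-fold lower number from compound 1 to compound 3 (0.00 log units; that floor lies within the scatter), which exchanges that group for cyclohexyl. The step of an at least 1.5-fold lower number from compound 1 to compound 2 (0.17 log units; that floor lies within the scatter) also bears on it, and neither shows a size beyond the scatter. No step beyond the scatter is therefore expected in this assay, in either direction. The expected change is a 1.1-fold lower number from compound 3 to compound 4 (0.04 log units; within the scatter), which would stay within the scatter. Compound 4 is estimated at 90000 nM, with an expected range from 50000 nM to 150000 nM.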

Compound 4, half-maximal inhibitory concentration: 82500 nM
Estimate against measurement, compound 4: 1.1-fold (0.04 log units) above; low and high end bracket the measured number.
By their numbers in this assay, from the lowest: compounds 2, 4 and 3 (each within the scatter of the next). At a limit, above all of these: compound 1.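

In this assay, the exchange of a saturated ring for an aromatic one on a saturated chain carbon bound to a sulfur can now be read between two numbers rather than from a limit, and 4-methylphenyl in place of cyclohexyl gives a 1.2-fold lower number from compound 3 to compound 4 (0.08 log units; within the scatter). The exchange of 4-methylphenyl for benzyl at the same place gives a 1.2-fold higher number from compound 2 to compound 4 (0.10 log units; within the scatter), so neither of the two changes with a numerical value at both ends moves the read-out beyond the scatter. Methyl in place of chloro on an aromatic carbon gives an at least 1.2-fold lower number from compound 1 to compound 4 (0.08 log units; that floor lies within the scatter), and since compound 1 stands at a limit of the assay, this step has only a floor and its true size stays unknown: the limit of > 100000 nM in this assay, at which 1 of the 4 values shown sits.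

From the compounds shown here alone, all four compounds carry a ring of carbon only in this place, so it remains open whether an amine or a carboxylic acid on that ring, or a piperidine in its place, would shift the number beyond the scatter in this assay. Going by these compounds, it is also open whether a plain methyl or a longer unbranched alkyl chain on the sulfur, with no ring at all, would do so.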